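Replacing the Amide Substituent of Compound 1

The source may hold more compounds than are shown below. What is called first, only, known or untested is meant among the compounds shown, and "the series" means these compounds.

Compound 1 `COc1cccc(OC)c1C(=O)Nc1c[nH]nc1C(=O)N[C@H]1CC[C@H](OC)CC1` was measured in an ADME assay on MRC5 cells (Homo sapiens) for inhibition, with a stated time of 72 h (on this read-out lower numbers stand for an effect already at smaller amounts and higher numbers for an effect only at larger amounts of compound), where compound 1 gives 31000 nM. Of the two numbers shown for this read-out it stands highest; its nearest neighbour is compound 3 `COc1ccccc1C(=O)Nc1c[nH]nc1C(=O)N[C@H]1CC[C@H](OC)CC1`, which in this assay gives 1500 nM, a 21-fold lower number from compound 1 to compound 3 (1.32 log units; beyond the scatter) that comes with hydrogen in place of methoxy on an aromatic carbon. Compound 2 `COc1cc(OC)c(C(=O)Nc2c[nH]nc2C(=O)N[C@H]2CC[C@H](OC)CC2)c(OC)c1` reaches only (the limit of > 50000 nM in this assay, at which 1 of the 3 values shown sits). In this assay compound 2 gives > 50000 nM, a limit rather than a number. The step of an at least 1.6-fold higher number from compound 1 to compound 2 (0.20 log units; that floor lies within the scatter) comes with methoxy in place of hydrogen on an aromatic carbon.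

Compound 4 `COc1cccc(OC)c1C(=O)Nc1c[nH]nc1C(=O)Nc1ccncc1` has not yet been measured. It differs from compound 1 by pyridin-4-yl in place of 4-methoxycyclohexyl on an amide-type nitrogen. Both measured steps concern an aromatic carbon, and neither touches the amide-type nitrogen, so neither bears directly on this change. Without a comparable step to draw on, no step beyond the scatter is expected in this assay in either direction, though the range must stay wide. Compound 4 is therefore estimated at 25000 nM, between 6000 nM and 50000 nM. The expected step of a 1.2-fold lower number from compound 1 to compound 4 (0.09 log units; within the scatter) is accordingly small.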

Compound 4, half-maximal effective concentration: > 50000 nM
Compound 4 ended at the assay's limit; the forecaster's own chance of this, stated with the estimate: 35%; middle value at least 2.0-fold (0.30 log units) away from the limit.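

In this assay compound 4 gives > 50000 nM, which is a limit of the assay and not a number. This is the first change shown on the amide-type nitrogen rather than on an aromatic carbon, and the step, an at least 1.6-fold higher number from compound 1 to compound 4 (0.20 log units; that floor lies within the scatter), means that pyridin-4-yl in place of 4-methoxycyclohexyl brought no lower number, while the one clear lowering shown so far, a 21-fold lower number from compound 1 to compound 3 (1.32 log units; beyond the scatter), came from a change on an aromatic carbon. The limit of the read-out has now been reached through changes in two different places, on an aromatic carbon in compound 2 and on the amide-type nitrogen in compound 4: the limit of > 50000 nM in this assay, at which 2 of the 4 values shown sit.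

On these data alone, how far compound 4 lies past that limit stays unknown, so the true size of its step from compound 1 cannot be told, and a single replacement says little about this position as a whole. Also open, as far as these compounds go, is whether a plain cyclohexyl, a piperidin-4-yl or a short chain such as ethyl on this amide-type nitrogen would give a number inside the range of this assay, and whether any of them would fall clearly lower than compound 1.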